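A few compounds are considered here, and "the series" means these few. Any claim that something is new, unique, unknown or untested is made for them only; others in the source may bear on it.

Measured so far in an assay on CHO-TREX cells for antagonist activity at transient receptor potential cation channel subfamily A member 1 (Homo sapiens), read by FLIPR and calcium flux, with a stated time of 10 min; on this read-out higher numbers stand for weaker inhibition and lower numbers for stronger inhibition:
Compound 1 `Fc1cccc(C(F)(F)F)c1-c1ccc2[nH]ncc2c1` gives 1230 nM.
Compound 2 `Fc1c(-c2ccccc2C(F)(F)F)ccc2[nH]ncc12` gives 296 nM.
Compound 3 `Fc1cc2[nH]ncc2cc1-c1ccccc1C(F)(F)F` gives 48 nM.

All three carry the same shared core and the same trifluoromethyl-bearing phenyl; they differ only in where a fluoro sits. Compound 3 stands lowest of the three numbers in this assay. The nearest number is that of compound 2, and the gap lies beyond the scatter; the furthest is that of compound 1, also beyond the scatter. No pair among the measured compounds differs in a single place, so no step has been quantified within the set, and nothing can be said about why one fluoro placement reads lower than another.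

Compound 4 `N#Cc1cc2[nH]ncc2cc1-c1ccccc1C(F)(F)F` has not yet been measured. It differs from compound 3 in one place: cyano in place of fluoro on an aromatic carbon. Going by the values given here, the set holds no precedent for a fluoro-to-cyano exchange at this position, so the direction of the step cannot be read from earlier pairs. The working expectation is a step of modest size, if any, with a lean toward a somewhat higher number: the estimated step is a 1.7-fold higher number from compound 3 to compound 4 (0.22 log units; within the scatter). Compound 4 is expected to give 80 nM, with a range from 25 nM to 300 nM.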

Compound 4, half-maximal inhibitory concentration: 129 nM
The estimate for compound 4 lay 1.6-fold (0.21 log units) below the measured number; the range from low to high includes it.
By their numbers in this assay, from the lowest: compound 3; then compound 4; then compound 2; then compound 1.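

In this assay, cyano in place of fluoro on this aromatic carbon, ortho to a large group, gives a 2.7-fold higher number from compound 3 to compound 4 (0.43 log units; beyond the scatter), a modest step beyond the scatter and the first single-place change quantified in the series. The position thus responds to what it carries, yet the exchange does not abolish inhibition: with the larger cyano and its added hydrogen-bond acceptor, compound 4 still reads 129 nM. Nothing in the data bears on what lies behind the step, so it stands as an observation only.

From the compounds shown here alone, whether the step is specific to cyano or would follow from any replacement of fluoro at this carbon remains open; a chlorine, a methyl or an amine at the same place would show where fluoro and cyano stand among other groups. Also open, going by these compounds, is whether the same exchange made on compound 1 or on compound 2, with fluoro in their placements, would move the number in the same direction and by a similar size.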